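Methyl for methoxy on the aryl ring: compound 3

This account rests on a few compounds, and the source may have more. Where it says the series, first, only, none or still open, it means among the compounds named here.

Measured so far:
compound 1, `CCn1nnnc1-c1sc(-c2cccc(F)c2)nc1O` — > 100000 nM in an assay on HEK293 cells for inhibition of transient receptor potential cation channel subfamily M member 8 (Homo sapiens), read by FLIPR, with stated times of 5 min and 3 min (a higher number here means a weaker inhibitor, a lower number a stronger inhibitor), a limit of the assay, not a number
compound 2, `CCn1nnc(-c2sc(-c3cccc(OC)c3)nc2O)n1` — 245 nM in this assay

Among the measured compounds shown here, compound 2 holds the only number in this small set. Compound 1 sits at the limit of > 100000 nM in this assay, at which 1 of the 2 values shown sits, a bound rather than a measurement. For the measured compounds named here, no step between the two can therefore be sized, and nothing is known about how this series answers to a change on the aryl ring.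

Compound 3, `CCn1nnc(-c2sc(-c3cccc(C)c3)nc2O)n1`, is not yet measured. It differs from compound 2 in one place: methyl in place of methoxy on an aromatic carbon.

With no measured step of this kind in the series, the change is expected to be small, at about a 1.2-fold higher number from compound 2 to compound 3 (0.09 log units; within the scatter) in this assay, with no clear direction beyond the scatter. Compound 3 is accordingly estimated at 300 nM in this assay, with a range from 100 nM to 1000 nM. The anchor is compound 2 because it gives 245 nM.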

Compound 3, half-maximal inhibitory concentration: 369 nM
The estimate for compound 3 lay 1.2-fold (0.09 log units) below the measured number; the measured number falls inside the stated range.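

In this assay the series now has its first measured step, a 1.5-fold higher number from compound 2 to compound 3 (0.18 log units; within the scatter) for methyl in place of methoxy on an aromatic carbon, meta to a large group. At this position, then, the hydrogen-bond acceptor of the methoxy is not required for compound 3 to stay within the scatter of compound 2, and a group without oxygen serves as well in this pair. Nothing shown gives a reason for this step.

As far as these compounds go, how far this position accepts groups unlike these two, such as an amine, a carboxylic acid or a longer chain like butoxy, stays open. Compound 1 gives > 100000 nM, a limit and not a number, and it differs from compound 2 in more than one place, so that step cannot be read.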